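Cyclobutyl in Place of a Morpholinylpropyl Chain

A few compounds are considered here, and "the series" means these few. Any claim that something is new, unique, unknown or untested is made for them only; others in the source may bear on it.

This account concerns three measured compounds and one that awaits measurement, all sharing one core. Compound 1 `CNC(=O)c1cc(C(=O)NCCCC2CNCCO2)cn(Cc2ccccc2)c1=O` gives 1.4 in a physicochemical assay for lipophilicity, at pH 7.4; on this read-out higher numbers stand for higher lipophilicity and lower numbers for lower lipophilicity. Compound 2 `CNC(=O)c1cc(C(=O)NC2CC2)cn(Cc2cccc3[nH]c(C)nc23)c1=O` gives 1.5 in this assay, a number within the scatter of that of compound 1, so the two cannot be ordered. Compound 3 `CNC(=O)c1cc(C(=O)NC2CC2)cn(Cc2cccc(C)c2)c1=O` gives 3.6 in this assay, a number well beyond the scatter above compound 1. No two of these three differ in just one place, so their values stand side by side without a single counted step between them.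

Compound 4 `CNC(=O)c1cc(C(=O)NC2CCC2)cn(Cc2ccccc2)c1=O` has not yet been measured. It differs from compound 1 in one place: cyclobutyl in place of 3-(morpholin-2-yl)propyl on an amide-type nitrogen. A large upward step is expected in this assay, reading a number 1.90 log units higher from compound 1 to compound 4 (beyond the scatter), because compound 3 already gives 3.6 while carrying no such chain. For compound 4 the estimate in this assay is 3.3, with a range from 2.7 to 3.9.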

Compound 4, distribution coefficient: 3.8
Compound 4: the middle estimate sits 0.50 log units below what was measured; the range from low to high includes it.
By their numbers in this assay, from the lowest: compounds 1 and 2 (each within the scatter of the next); then compounds 3 and 4 (each within the scatter of the next).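

In this assay, within the data shown here, cyclobutyl in place of 3-(morpholin-2-yl)propyl on an amide-type nitrogen gives a number 2.40 log units higher from compound 1 to compound 4 (beyond the scatter) and so provides the first counted step in this set, showing that a change at this one position alone can move the read-out by a large amount. The step replaces a chain-borne ring with hetero atoms, hydrogen-bond donor and acceptors by an all-carbon ring with none of these, so several differences travel together in this single change. No measurement shown here bears on what lies behind the size of this step.

The compounds shown leave open how much of the step follows the ring and how much the chain, which a plain propyl chain or a morpholin-2-yl group placed directly on the same nitrogen would separate. They also leave open whether a primary amine on the cyclobutyl ring would keep the number near that of compound 4.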